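Fluorine Out, Methyl In: A Step Not Yet Measured

This account rests on a few compounds, and the source may have more. Where it says the series, first, only, none or still open, it means among the compounds named here.

Measured so far in an assay on isolated protein for inhibition of Amine oxidase [flavin-containing] A (Homo sapiens), read by fluorescence, with a stated time of 15 min; a lower number here means a stronger inhibitor, a higher number a weaker inhibitor:
Compound 1 `CCOc1ccc2cc(C(=O)/C=C/c3c(/C=C/c4ccc(OC)cc4)cc(OC)cc3OC)c(=O)oc2c1` gives 7070 nM
Compound 2 `COc1ccc(/C=C/c2cc(OC)cc(OC)c2/C=C/C(=O)c2cc3cc(F)ccc3oc2=O)cc1` gives 44300 nM

Of the two numbers, compound 2 carries the higher one, and its gap to compound 1 lies beyond the scatter, so compound 2 is the weaker inhibitor of this pair. The unmeasured compound 3 `COc1ccc(/C=C/c2cc(OC)cc(OC)c2/C=C/C(=O)c2cc3ccc(C)cc3oc2=O)cc1` differs from compound 2 by a group of 12 heavy atoms (10 carbon, 2 oxygen; one six-membered aromatic ring of carbon only, one six-membered aromatic ring with 1 hetero atom) in place of a group of 12 heavy atoms (9 carbon, 2 oxygen, 1 fluorine; one six-membered aromatic ring of carbon only, one six-membered aromatic ring with 1 hetero atom), on a carbonyl carbon, a fluorine giving way to a methyl on the same ring. For the measured compounds named here, no step between two measured compounds mirrors this exchange, so there is no direct precedent for its size. The two values shown only say that the ring carrying this substituent tolerates variation with a large effect. Compound 3 is expected to land a moderate step from a 2.2-fold lower number from compound 2 to compound 3 (0.35 log units; beyond the scatter) toward a lower number, with wide uncertainty. The estimate for compound 3 is 20000 nM, between 6000 nM and 60000 nM.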

Compound 3, half-maximal inhibitory concentration: 58200 nM
Compound 3: the middle estimate sits 2.9-fold (0.46 log units) below what was measured, and the stated range covers the measured number.
By their numbers in this assay, from the lowest: compound 1; then compounds 2 and 3 (each within the scatter of the next).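

In this assay, methyl in place of fluorine on the same ring gives a 1.3-fold higher number from compound 2 to compound 3 (0.12 log units; within the scatter), so the two substituents cannot be told apart in this pair. Methyl in place of ethoxy on an aromatic carbon gives an 8.2-fold higher number from compound 1 to compound 3 (0.92 log units; beyond the scatter), the first single exchange shown with an effect beyond the scatter, and compound 1, which carries the ethoxy group, has the lower number. Nothing available explains either result.

On these data alone, it stays open whether a methoxy group, a longer chain such as propoxy, or an amine on that aromatic carbon would give a number nearer that of compound 1 or of compound 3. As far as these compounds go, only compound 1 carries ethoxy, so it is also open whether that group would give a lower number than methyl on any other core.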